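The source may report more compounds than this note shows. Statements on the series, on what has been measured and on what is new or still open speak of the compounds shown alone.

In an ADME assay on microsomes from liver (Rattus norvegicus, strain Wistar) for metabolic stability, tested at 2.5 uM (on this read-out lower numbers stand for slow clearance and higher numbers for fast clearance), three compounds have been measured so far:
compound 1 `Clc1ccc(Cn2nnc3c(Br)cccc32)cc1` gives 2.2 mL/min/g;
compound 2 `Brc1ccc(Cn2nnc3c(Br)cccc32)cc1` gives 2.2 mL/min/g;
compound 3 `Brc1cc(Br)c2nnn(CC3CC3)c2c1` gives 2.3 mL/min/g.

Compound 1 and compound 2 share one core, while compound 3 is built on another; the difference between the two cores is not broken down here. Compound 1 differs from compound 2 in a single place: chloro in place of bromo on an aromatic carbon. In this assay that exchange made no difference, no change at the digits printed from compound 2 to compound 1 (within the scatter). The value of compound 3 lies within the scatter of the values of compound 1 and compound 2, so no order can be read among the three.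

Compound 4 `Clc1cc(Br)c2nnn(CC3CC3)c2c1` has not yet been measured. It differs from compound 3 by the same kind of change, (chloro in place of bromo on an aromatic carbon). The surroundings differ, though: in compound 4 the ring is part of a fused system of two rings and the carbon is meta to a bromo group, meta to a fused ring and para to a fused ring, whereas in compound 1 the carbon is para to a large group. Within the data shown here, the one measured example of this exchange, no change at the digits printed from compound 2 to compound 1 (within the scatter), is the only ground for an expectation. On that ground the step of no change at the digits printed from compound 3 to compound 4 (within the scatter) is expected, because no change at the digits printed from compound 2 to compound 1 (within the scatter) showed no movement. Compound 4 is therefore estimated at 2.3 mL/min/g, most likely falling between 1.5 mL/min/g and 3.5 mL/min/g.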

Compound 4, intrinsic clearance in a liver preparation (reported as CLH), per the amount of preparation that the assay uses: 1.1 mL/min/g
For compound 4 the middle estimate is 2.1-fold (0.32 log units) above the measured one, outside the stated range (below it).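

In this assay, chloro in place of bromo on the core of the later pair gives a 2.1-fold lower number from compound 3 to compound 4 (0.32 log units; beyond the scatter), a modest step that, taken alone, stands clear of the usual scatter. Set beside the earlier step on the other core, however, the two results lie no further apart than repeated measurements of such steps can: the same change on two cores in this assay, no change at the digits printed (within the scatter) from compound 2 to compound 1 and a 2.1-fold lower number (0.32 log units; beyond the scatter) from compound 3 to compound 4, 2.1-fold (0.32 log units) apart, within the scatter of two such steps. This shows no real dependence of the exchange on the core, but two examples cannot prove that the exchange carries over unchanged either, and they give no explanation for the lower number seen on one core.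

As far as these compounds go, it remains open whether the same step would appear on further cores, or if the remaining bromo group of compound 4 were exchanged as well. From the compounds shown here alone, it is also open how other groups in that place, such as fluoro, methyl, a nitrile or an amine, would compare with chloro and bromo on this read-out.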